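A few compounds are considered here, and "the series" means these few. Any claim that something is new, unique, unknown or untested is made for them only; others in the source may bear on it.

Of the compounds shown here, three sharing one core have been measured in an assay on THP-1 cells for displacement of a labelled ligand from C-C chemokine receptor type 1 (Homo sapiens); on this read-out lower numbers stand for stronger inhibition and higher numbers for weaker inhibition. Compound 1 `CC(C)[C@@H](NC(=O)c1ccc(F)cc1)C(=O)N1CCC(c2ccc(Cl)cc2)CC1` gives 118 nM, compound 2 `CC(C)[C@@H](NC(=O)CCCc1ccccc1)C(=O)N1CCC(c2ccc(Cl)cc2)CC1` gives 95 nM, and compound 3 `CC(C)[C@@H](NC(=O)C1CCCC1)C(=O)N1CCC(c2ccc(Cl)cc2)CC1` gives 70 nM. Compound 3 has the lowest of the three numbers, yet every gap to it is small: a 1.7-fold lower number from compound 1 to compound 3 (0.23 log units; within the scatter) and a 1.4-fold lower number from compound 2 to compound 3 (0.13 log units; within the scatter), so none of the three can be called stronger than another on this evidence. The remaining pair behaves alike, with a 1.2-fold lower number from compound 1 to compound 2 (0.09 log units; within the scatter).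

Compound 4 `CC(C)[C@@H](NC(=O)CC1CC1)C(=O)N1CCC(c2ccc(Cl)cc2)CC1` is not yet measured. It differs from compound 3 by cyclopropylmethyl in place of cyclopentyl on a carbonyl carbon. All three measured steps swap the group on the same carbonyl carbon, between an aromatic ring, a chain ending in an aromatic ring and a saturated ring, and each stayed within the scatter. That record suggests this position tolerates varied groups, so the step from compound 3 to compound 4 is expected to be small, a 1.3-fold higher number from compound 3 to compound 4 (0.11 log units; within the scatter), with perhaps a slightly higher number. Compound 4 is therefore estimated at 90 nM in this assay, within a range of 40 nM to 220 nM.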

Compound 4, half-maximal inhibitory concentration: 46 nM
Estimate against measurement, compound 4: 2.0-fold (0.29 log units) above, within the range that was stated.
By their numbers in this assay, from the lowest: compounds 4, 3, 2 and 1 (each within the scatter of the next, the first and the last beyond it).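

Cyclopropylmethyl and cyclopentyl cannot be told apart at this carbonyl carbon in this assay, with a 1.5-fold lower number from compound 3 to compound 4 (0.18 log units; within the scatter). Yet the position is not wholly indifferent, as cyclopropylmethyl gives the first steps in this set that pass the scatter, a 2.1-fold lower number from compound 2 to compound 4 (0.31 log units; beyond the scatter) and a 2.6-fold lower number from compound 1 to compound 4 (0.41 log units; beyond the scatter), both modest, although compound 3, with cyclopentyl, stays within the scatter of compound 1 and compound 2. Nothing available here explains these differences.

The compounds shown leave open how a plain cyclopropyl, an unbranched butyl chain or a cyclopentyl ring carrying an amine would behave on this carbonyl carbon. They also leave open whether the same steps would hold with anything other than the shared core, since all four compounds keep it unchanged.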